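The source may report more compounds than this note shows. Statements on the series, on what has been measured and on what is new or still open speak of the compounds shown alone.

For the measured compounds named here, compound 3 `Cc1nnsc1CO/N=C/c1c(C)nn(C)c1Cl` is the only member of this small set that returns a number in a functional assay on PANC-1 cells (Homo sapiens) for inhibition, read by MTT assay, with a stated time of 48 h; on this read-out higher numbers stand for weaker inhibition and lower numbers for stronger inhibition: compound 3 gives 26600 nM. Compound 1 `CCCc1nnsc1CO/N=C/c1c(C)nn(C)c1Oc1ccc(F)cc1` gives only a limit in this assay, > 50000 nM. Compound 2 `CCCc1nnsc1CO/N=C/c1c(C)nn(C)c1Oc1ccc(Cl)cc1` also gives only a limit in this assay, > 50000 nM. The step from compound 1 to compound 2, a step that the two limits leave unreadable from compound 1 to compound 2, is therefore of unreadable size, since both values sit at the limit of > 50000 nM in this assay, at which 2 of the 3 values shown sit.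

Compound 4 `CCCc1nnsc1CO/N=C/c1c(C)nn(C)c1Cl` differs from compound 3 by ethyl in place of hydrogen on a saturated chain carbon bound to an aromatic carbon; cut one bond further out, the same difference reads methyl to propyl. Going by the values given here, no measured step bears on this change. Among the compounds with values here, the only step between measured compounds, the exchange of fluoro for chloro, is unreadable, and compounds 1 and 2, which carry the propyl chain, differ from compound 3 in a second place as well, so their limits say nothing about the chain on its own.

With nothing in the measured steps pointing either way, the expected step of a 1.0-fold lower number from compound 3 to compound 4 (0.01 log units; within the scatter) is none beyond the scatter. Because compound 3 gives 26600 nM, compound 4 is expected to give 26000 nM in this assay, with a range from 9000 nM to 60000 nM.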

Compound 4, half-maximal inhibitory concentration: > 50000 nM
Compound 4 was reported as a limit; the forecaster's own chance of this, stated with the estimate: 25%; at least 1.9-fold (0.28 log units) between middle value and limit.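

With the step from the methyl to the propyl chain, the set gains its first comparison that is not wholly closed by limits: in this assay, ethyl in place of hydrogen on a saturated chain carbon bound to an aromatic carbon gives an at least 1.8-fold higher number from compound 3 to compound 4 (0.27 log units; that floor lies within the scatter). This figure is only a floor, and since it lies within the scatter, it does not establish that the longer chain weakens inhibition, although the chain change now has a measured pair of its own, which compounds 1 and 2 could not provide. The steps from compound 1 to compound 4 and from compound 2 to compound 4 cannot be read, so replacing either phenoxy group with chloro has no measurable size, and compound 4 joins the two at the same limit of the assay: the limit of > 50000 nM in this assay, at which 3 of the 4 values shown sit.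

As far as these compounds go, the true size of the chain effect remains open, as the value of compound 4 is a limit and not a number. Also open, from the compounds shown here alone, is how an ethyl or a butyl chain at this place, or an amine carried on the chain, would read against compound 3 with the rest of the core unchanged.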